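A Trifluoromethyl Swap at the Assay Limit

The compounds below may be only part of what the source reports. "The series", "measured", "known", "first", "only" and "open" are said of these compounds alone.

In a functional assay on NALM-6 cells (Homo sapiens) for cytotoxicity, with a stated time of 72 h (a higher number here means that more compound is needed for the effect, a lower number that less compound is needed), compound 1 `CCOc1ccc(/C=C/[C@@](C)(/C=C/c2ccc(O)cc2)CCC=C(C)C)cc1` gives > 43400 nM as a limit of the assay and not a number. Compound 2 `C=C[C@@](C)(/C=C/c1ccc(Nc2ccc(OC(F)(F)F)cc2)cc1)CCC=C(C)C` gives > 43400 nM which is likewise only a limit. Compound 2 thus stands at the limit of > 43400 nM in this assay, at which 2 of the 2 values shown sit, with no number of its own. Compound 3 `C=C[C@@](C)(/C=C/c1ccc(Nc2ccc(C(F)(F)F)cc2)cc1)CCC=C(C)C` carries trifluoromethyl in place of trifluoromethoxy on an aromatic carbon. Within the data shown here, with no step to go on in this assay the expected step of a number no higher from compound 2 to compound 3 (the limit leaves the size open) is none beyond the scatter in either direction. Compound 3 is estimated at 43400 nM (expected range 20000 nM to 87000 nM).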

Compound 3, half-maximal effective concentration: > 43400 nM
Compound 3: a limit, no number; the forecaster's own chance of this, stated with the estimate: 75%; the middle value sits exactly at the limit.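

Compound 2 and compound 3 both return only a limit of the assay and not a number, so no step can be read between them: the limit of > 43400 nM in this assay, at which 3 of the 3 values shown sit. The compounds shown leave open whether trifluoromethyl and trifluoromethoxy differ here at all, and what potency any of the three compounds has.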